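The source may hold more compounds than are shown below. What is called first, only, known or untested is meant among the compounds shown, and "the series" means these compounds.

Measured so far:
compound 1 `CCCC(C#N)(CCC)Nc1nc(NC)nc(-n2cncn2)n1`, 32 mL/min/kg
compound 2 `CNc1nc(NC2(C#N)CCCCC2)nc(OC)n1`, 196 mL/min/kg
compound 3 `CNc1nc(NC(C#N)(C2CC2)C2CC2)nc(-n2cncn2)n1`, 3.7 mL/min/kg

Of the compounds shown here, three have been tested in an ADME assay on microsomes from liver (Rattus norvegicus) for metabolic stability; a lower number here means slower removal, a higher number faster removal of the compound. Compound 2 gives 196 mL/min/kg, the highest of the three numbers. Compound 1 gives 32 mL/min/kg, and compound 3 gives 3.7 mL/min/kg, both well beyond the scatter below compound 2, so compound 2 is clearly the fastest removed of the three.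

The new compound, compound 4 `CNc1nc(NC2(C#N)CCCCC2)nc(N2CCCC2)n1`, keeps everything of compound 2 except one spot on the shared core: pyrrolidin-1-yl in place of methoxy on an aromatic carbon. Among the compounds with values here, none of the measured pairs differs in exactly this way, so no measured step shows how large such a change tends to be here.

With nothing directly comparable to lean on, the step in this assay from compound 2 to compound 4 is expected to be modest and to point towards a lower number, though it may well stay within the scatter; the expected step is a 1.5-fold lower number from compound 2 to compound 4 (0.18 log units; within the scatter). Compound 4 is therefore estimated at 130 mL/min/kg, with a range from 55 mL/min/kg to 300 mL/min/kg.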

Compound 4, clearance: > 276 mL/min/kg
Compound 4 gave a limit, no number (the forecaster's own chance of this, stated with the estimate: 5%); middle value at least 2.1-fold (0.32 log units) away from the limit.
By their numbers in this assay, from the lowest: compound 3; then compound 1; then compound 2. At a limit, above all of these: compound 4.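

In this assay, putting pyrrolidin-1-yl in place of methoxy on this aromatic carbon, the one opposite the ring nitrogen, gives an at least 1.4-fold higher number from compound 2 to compound 4 (0.14 log units; that floor lies within the scatter). Within the data shown here, this is the first direct look at a change at this position, and it shows that the larger ring does not bring the number down from the already high reading of compound 2, so the modest drop that seemed possible did not appear. The reading for compound 4 is a limit of the assay and not a number: the limit of > 276 mL/min/kg in this assay, at which 1 of the 4 values shown sits.

From the compounds shown here alone, the true distance between compound 2 and compound 4 therefore stays open, since only a floor is known and that floor lies within the scatter. Also open, going by these compounds, is how a plain amine or a morpholine ring on this same carbon would read against methoxy.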